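Imine aryl swap on the shared core: methoxy to chloro

The compounds below may be only part of what the source reports. "The series", "measured", "known", "first", "only" and "open" are said of these compounds alone.

Two compounds of the series have been run in a functional assay on HT-29 cells (Homo sapiens) for cytotoxicity, read by MTT assay, with a stated time of 72 h; a lower number here means a stronger inhibitor, a higher number a weaker inhibitor. Compound 1 `COc1ccc(/C=N/c2c(C)n(C)n(-c3ccccc3)c2=O)cc1OC` gives 603000000 nM. Compound 2 `COc1ccccc1/C=N/c1c(C)n(C)n(-c2ccccc2)c1=O` gives 70800000 nM, the lower of the two numbers; the gap from compound 2 up to compound 1 lies beyond the usual scatter, so compound 2 stands as the stronger inhibitor of the pair, although both numbers sit far from any useful potency.

Compound 3 `Cc1c(/N=C/c2cccc(Cl)c2)c(=O)n(-c2ccccc2)n1C` has not yet been measured. It differs from compound 2 in one place: 3-chlorophenyl in place of 2-methoxyphenyl on a carbon with a double bond to nitrogen. Within the data shown here, no measured step of this kind exists in the set, so neither the size nor the direction of the change can be read from earlier data. Among the measured compounds shown here, the only guide is that compound 2 at 70800000 nM and compound 1 at 603000000 nM both remain very weak, and a single aryl swap is not expected to move the number far. For compound 3 a step of a 1.4-fold higher number from compound 2 to compound 3 (0.15 log units; within the scatter) is expected, a slight weakening that stays within the scatter. Compound 3 is therefore estimated at 100000000 nM, with a range from 20000000 nM to 500000000 nM.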

Compound 3, half-maximal inhibitory concentration: 269000000 nM
For compound 3 the middle estimate is 2.7-fold (0.43 log units) below the measured one; measured number inside the range.
By their numbers in this assay, from the lowest: compound 2; then compound 3; then compound 1.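

Among these compounds, replacing 2-methoxyphenyl with 3-chlorophenyl on a carbon with a double bond to nitrogen gives the first measured step. In this assay it runs a 3.8-fold higher number from compound 2 to compound 3 (0.58 log units; beyond the scatter), so the number at this position does respond to this aryl swap, and here the change goes toward a weaker inhibitor. The entering group has 0 hydrogen-bond acceptors where the leaving group has 1, but the substituent and its place on the ring change together in this one step, and nothing available explains the shift.

Still open, going by these compounds, is whether the step follows from the chlorine, from the loss of the methoxy group or from the changed place on the ring, and a single pair cannot separate these. Also open, on these data alone, is whether an aryl group carrying an amine or a carboxylic acid at this position would bring the number anywhere near a useful potency, given that compound 2, the lowest of the three, still stands at 70800000 nM.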